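Sulfonyl for carbonyl on the ring nitrogen: compound 4

The compounds below may be only part of what the source reports. "The series", "measured", "known", "first", "only" and "open" are said of these compounds alone.

In a functional assay on HCC1806 cells (Homo sapiens) for inhibition, read by sulforhodamine B assay, tested at 10 uM (on this read-out higher numbers stand for more inhibition at the one concentration tested (going by the name of the read-out) and lower numbers for less inhibition), compound 1 `CC(=O)N1N=C(c2ccc(N3CCN(C)CC3)cc2)CC1c1ccc(N(C)C)cc1` gives -0.8%, compound 2 `CN1CCN(c2ccc(C3=NN(C(=O)c4ccc(F)cc4)C(c4ccc(N(C)C)cc4)C3)cc2)CC1` gives 31.8% and compound 3 `CN1CCN(c2ccc(C3=NN(C(=O)/C=C/c4ccccc4)C(c4ccc(N(C)C)cc4)C3)cc2)CC1` gives 71%, the highest of the three. Both steps into compound 3 were large: a number 71.8 percentage points higher from compound 1 to compound 3 (beyond the scatter) and a number 39.2 percentage points higher from compound 2 to compound 3 (beyond the scatter). Compound 4 `CN1CCN(c2ccc(C3=NN(S(=O)(=O)c4ccc(F)cc4)C(c4ccc(N(C)C)cc4)C3)cc2)CC1` differs from compound 3 in one place: (4-fluorophenyl)sulfonyl in place of (2-phenylethenyl)carbonyl on an amine nitrogen in a ring. Among the compounds with values here, no measured step covers a sulfonyl on this nitrogen; the only bearing step is the reverse of a number 39.2 percentage points higher from compound 2 to compound 3 (beyond the scatter), which set 4-fluorophenyl against 2-phenylethenyl on a carbonyl carbon. A large fall in this assay is therefore expected, a number 41 percentage points lower from compound 3 to compound 4 (beyond the scatter), with the sulfonyl adding uncertainty. The estimate for compound 4 is 30%, within 5% to 60%.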

Compound 4, a percentage reported as inhibition, at one concentration (the size of the read-out at that concentration, not a potency): 92.3%
For compound 4 the middle estimate is 62.3 percentage points below the measured one; measured number outside the range, above it.
By their numbers in this assay, from the lowest: compound 1; then compound 2; then compound 3; then compound 4.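

With the 4-fluorophenyl held constant, sulfonyl in place of carbonyl on the ring nitrogen gives a large rise (a number 60.5 percentage points higher from compound 2 to compound 4 (beyond the scatter)), so the linking group at this position counts as well as the group it carries. The sulfonyl also surpasses the (2-phenylethenyl)carbonyl of compound 3 (a number 21.3 percentage points higher from compound 3 to compound 4 (beyond the scatter)) and the acetyl of compound 1 (a number 93.1 percentage points higher from compound 1 to compound 4 (beyond the scatter)), which puts compound 4 highest of the four. Nothing measured accounts for this gain.

On these data alone, whether a methylsulfonyl or a plain phenylsulfonyl on this nitrogen would hold the effect remains open. The single tested concentration also leaves potency open.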